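The source may report more compounds than this note shows. Statements on the series, on what has been measured and on what is new or still open speak of the compounds shown alone.

Three related compounds have been read out in an ADME assay on HepG2 2.2.15 cells (Homo sapiens) for cytotoxicity; on this read-out lower numbers stand for higher toxicity in this test and higher numbers for lower toxicity in this test. Compound 1 `O=c1c(CCO)c(-c2ccccc2Cl)c2cc(Cl)ccc2n1-c1ccccc1` gives 26000 nM, compound 2 `O=CCc1c(-c2ccccc2Cl)c2cc(Cl)ccc2[nH]c1=O` gives 120000 nM, and compound 3 `CCCC(=O)OCCc1c(-c2ccccc2Cl)c2cc(Cl)ccc2[nH]c1=O` gives 52000 nM. Compound 3 therefore lies within the scatter of compound 1 , while its number stands below that of compound 2 by a margin beyond the scatter.

Compound 4 `O=C(O)CCCC(=O)OCCc1c(-c2ccccc2Cl)c2cc(Cl)ccc2[nH]c1=O` differs from compound 3 in one place: carboxy in place of hydrogen on a saturated chain carbon, three bonds along the chain from a carbonyl carbon. The carboxy takes the place of a hydrogen on a saturated chain carbon, three bonds along the chain from a carbonyl carbon.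

Among the compounds with values here, only one measured step bears on this part of the molecule. It is a 2.3-fold lower number from compound 2 to compound 3 (0.36 log units; beyond the scatter), a modest change beyond the scatter in which ((propylcarbonyl)oxy)methyl replaces formyl. Within the data shown here, no measured pair shows what adding a carboxy does, so that step suggests a size but fixes no direction. A step no larger than that one is therefore expected in this assay, and most likely none beyond the scatter. The estimated change is a 1.3-fold higher number from compound 3 to compound 4 (0.10 log units; within the scatter). For compound 4 the expected value is 65000 nM, with an estimated range from 28000 nM to 150000 nM.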

Compound 4, half-maximal cytotoxic concentration: 110000 nM
Estimate against measurement, compound 4: 1.7-fold (0.23 log units) below; measured number inside the range.
By their numbers in this assay, from the lowest: compounds 1 and 3 (each within the scatter of the next); then compounds 4 and 2 (each within the scatter of the next).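

Read in this assay, the carboxy gives a 2.1-fold higher number from compound 3 to compound 4 (0.33 log units; beyond the scatter), a modest step beyond the scatter and the first direct measure of this change, which shows that the position three bonds along the chain from a carbonyl carbon is not silent and that, in this one pair, the change points towards lower toxicity in this test. It also qualifies the earlier step of a 2.3-fold lower number from compound 2 to compound 3 (0.36 log units; beyond the scatter), since the ester carrying the 3-carboxypropyl group gives a 1.1-fold lower number from compound 2 to compound 4 (0.04 log units; within the scatter), which lies within the scatter, so compound 4 cannot be told apart from compound 2 and the ester linkage alone does not fix a lower number. No measurement available here explains why the carboxy has this effect on the read-out.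

As far as these compounds go, what stays open is whether the step belongs to the carboxy itself, since an amine, a primary amide or a methyl ester at the same place would be needed to tell that group apart from any other added there. Also open, from the compounds shown here alone, are whether a longer chain ending in the same carboxylic acid would give a step of similar size, and whether the change would carry over to the core of compound 1.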